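Swapping the Sulfonyl Aryl Group: Expected Clearance of Compound 3

The compounds below may be only part of what the source reports. "The series", "measured", "known", "first", "only" and "open" are said of these compounds alone.

Going by the values given here, compound 1 `O=S(=O)(c1ccc(F)cc1)c1cnc2c(F)cccc2c1-c1cccc(F)c1` was tested in an ADME assay on microsomes from liver (Homo sapiens) for metabolic stability, tested at 2.5 uM (on this read-out lower numbers stand for slow clearance and higher numbers for fast clearance), and gave 1.56 mL/min, the lower of the two numbers known so far. Compound 2 `COc1cccc(-c2c(S(=O)(=O)c3ccc(F)cc3)cnc3c(F)cccc23)c1` gives 2.23 mL/min in this assay; the step of a 1.4-fold higher number from compound 1 to compound 2 (0.16 log units; within the scatter) accompanied methoxy in place of fluoro on an aromatic carbon. Compound 3 `N#Cc1cccc(S(=O)(=O)c2cnc3c(F)cccc3c2-c2cccc(F)c2)c1` differs from compound 1 by 3-cyanophenyl in place of 4-fluorophenyl on a sulfonyl sulfur. Among the compounds with values here, no measured step touches the group on the sulfonyl sulfur, and the only step available is within the scatter, so no shift beyond the scatter is expected in either direction. Compound 3 is therefore estimated to give 1.8 mL/min in this assay, between 0.9 mL/min and 3.6 mL/min, a step of a 1.2-fold higher number from compound 1 to compound 3 (0.06 log units; within the scatter).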

Compound 3, intrinsic clearance in a liver preparation (reported as CLH), per the amount of preparation that the assay uses: 0.34 mL/min
Compound 3: middle estimate off by 5.3-fold (0.72 log units), on the high side; measured number below the stated range.
By their numbers in this assay, from the lowest: compound 3; then compounds 1 and 2 (each within the scatter of the next).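

On the sulfonyl sulfur, the aryl group clearly matters in this assay: 3-cyanophenyl in place of 4-fluorophenyl brings a 4.6-fold lower number from compound 1 to compound 3 (0.66 log units; beyond the scatter), the first step shown to lie beyond the scatter. This position can therefore shift the read-out towards slower clearance, at least for this one change. Nothing measured here gives a cause for the step.

Still open, as far as these compounds go, is whether the nitrile alone accounts for the step, or the 3-cyanophenyl group as a whole. Also open, from the compounds shown here alone, is how an aminophenyl or a plain methyl group on the sulfonyl sulfur would behave.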